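Growth inhibition notes: 2,4-dichlorophenyl to 4-hydroxyphenyl

The source may hold more compounds than are shown below. What is called first, only, known or untested is meant among the compounds shown, and "the series" means these compounds.

- Compound 1 `O=S(=O)(/C=C/c1ccccc1)Cc1ccc(Nc2ncnc3ccccc23)cc1`: 74000 nM
- Compound 2 `N#Cc1ccc(/C=C/S(=O)(=O)Cc2ccc(Nc3ncnc4ccccc34)cc2)cc1`: > 100000 nM (a limit of the assay)
- Compound 3 `O=S(=O)(/C=C/c1ccc(Cl)cc1Cl)Cc1ccc(Nc2ncnc3ccccc23)cc1`: 4000 nM

Among the compounds with values here, in a functional assay on MCF7 cells (Homo sapiens) (on this read-out higher numbers stand for weaker inhibition of growth and lower numbers for stronger inhibition of growth), compound 3 gives 4000 nM, the lowest number so far. The next change leads to compound 4 `O=S(=O)(/C=C/c1ccc(O)cc1)Cc1ccc(Nc2ncnc3ccccc23)cc1`: 4-hydroxyphenyl in place of 2,4-dichlorophenyl on a double-bonded chain carbon bound to a double-bonded chain carbon. Here 4-hydroxyphenyl stands in place of 2,4-dichlorophenyl on a double-bonded chain carbon bound to a double-bonded chain carbon. Two large measured steps bear on this: a 19-fold lower number from compound 1 to compound 3 (1.27 log units; beyond the scatter) and an at least 25-fold lower number from compound 2 to compound 3 (1.39 log units; beyond the scatter). The step of an at least 1.3-fold higher number from compound 1 to compound 2 (0.13 log units; that floor lies within the scatter) has its floor within the scatter. Removing the 2,4-dichlorophenyl group is expected to reverse much of a 19-fold lower number from compound 1 to compound 3 (1.27 log units; beyond the scatter). The expected change is large and upward, a 10-fold higher number from compound 3 to compound 4 (1.00 log units; beyond the scatter). For compound 4 the estimate is 40000 nM, with an expected range of 10000 nM to 100000 nM.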

Compound 4, concentration for 50% growth inhibition: 100000 nM
Beside the measured number, compound 4's estimate is 2.5-fold (0.40 log units) below it, within the range that was stated.
By their numbers in this assay, from the lowest: compound 3; then compounds 1 and 4 (each within the scatter of the next).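

In this assay, 4-hydroxyphenyl in place of 2,4-dichlorophenyl at this place gives a 25-fold higher number from compound 3 to compound 4 (1.40 log units; beyond the scatter), a large step to weaker inhibition of growth. Hydroxy in place of hydrogen stays within the scatter (a 1.4-fold higher number from compound 1 to compound 4 (0.13 log units; within the scatter)), so among the rings shown, only 2,4-dichlorophenyl sets its compound apart from the phenyl of compound 1. Hydroxy in place of cyano gives a number no higher from compound 2 to compound 4 (the limit leaves the size open), and the size of this step cannot be read, because one end of it stands at a limit of the assay: the limit of > 100000 nM in this assay, at which 1 of the 4 values shown sits.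

Going by these compounds, whether a single chlorine on this ring would hold the lower number remains open. So does the reading of an amine or a carboxylic acid on the same ring.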